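The compounds below may be only part of what the source reports. "The series", "measured", "known", "first", "only" and "open" are said of these compounds alone.

Compound 1 `CC(C(=O)NCc1ccc(C(F)(F)F)nc1-c1cccc(Cl)c1)c1ccc(NS(C)(=O)=O)c(F)c1` gives 0.5 nM in an assay on CHO cells for antagonist activity at transient receptor potential cation channel subfamily V member 1 (Homo sapiens), read by FLIPR; on this read-out higher numbers stand for weaker inhibition and lower numbers for stronger inhibition. Compound 2 `CC(C(=O)NCc1ccc(C(F)(F)F)nc1-c1ccc(C(C)(C)C)cc1)c1ccc(NS(C)(=O)=O)c(F)c1` gives 0.5 nM in this assay. Compound 3 `CC(C(=O)NCc1ccc(C(F)(F)F)nc1-n1ccnc1)c1ccc(NS(C)(=O)=O)c(F)c1` gives 36.1 nM in this assay.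

Among these three numbers compound 3 stands highest, making it the weakest inhibitor of the set. Compound 4 `CC(C(=O)NCc1ccc(C(F)(F)F)nc1/C=C/c1ccccc1)c1ccc(NS(C)(=O)=O)c(F)c1` differs from compound 3 in one place: 2-phenylethenyl in place of 1H-imidazol-1-yl on an aromatic carbon. Within the data shown here, two measured steps bear on this change: a 72-fold higher number from compound 1 to compound 3 (1.86 log units; beyond the scatter) and a 72-fold higher number from compound 2 to compound 3 (1.86 log units; beyond the scatter). Both put the imidazolyl group in place of a six-membered aromatic ring of carbon only; compound 4 runs the other way, bringing such a ring back. A large fall in this assay is therefore expected, about a 36-fold lower number from compound 3 to compound 4 (1.56 log units; beyond the scatter). For compound 4 the estimate is 1 nM, with a range from 0.3 nM to 5 nM.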

Compound 4, inhibition constant: 2.2 nM
For compound 4 the middle estimate is 2.2-fold (0.34 log units) below the measured one; the measured number falls inside the stated range.
By their numbers in this assay, from the lowest: compounds 1 and 2 (each within the scatter of the next); then compound 4; then compound 3.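

In this assay, a carbon-only aromatic ring carried by 2-phenylethenyl recovers most of what the 1H-imidazol-1-yl compound lacks (a 16-fold lower number from compound 3 to compound 4 (1.22 log units; beyond the scatter)). The recovery is partial: the number stays above those with 3-chlorophenyl (a 4.4-fold higher number from compound 1 to compound 4 (0.64 log units; beyond the scatter)) and 4-(tert-butyl)phenyl (a 4.4-fold higher number from compound 2 to compound 4 (0.64 log units; beyond the scatter)), so this position accepts the double bond but does not reach their level. No measurement here explains these differences. Still open, from the compounds shown here alone, is whether an aromatic ring is needed at all: an amine or a longer carbon chain in this place would test that.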